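The compounds below may be only part of what the source reports. "The series", "measured", "known", "first", "only" and "open" are said of these compounds alone.

Of the compounds shown here, three share one core and have been tested in a functional assay on U2OS cells (Homo sapiens) for antiproliferative activity, read by MTT assay, with a stated time of 72 h; a lower number here means a stronger inhibitor, a higher number a weaker inhibitor. Compound 1 `CCOC1=C(C(=O)c2ccccc2)C(c2ccc(Br)cc2)N(CCCn2ccnc2)C1=O` gives 21900 nM there. Compound 2 `CCCCCOC1=C(C(=O)c2ccccc2)C(c2ccc(Br)cc2)N(CCCn2ccnc2)C1=O` gives 9140 nM in this assay. Compound 3 `O=C(C1=C(Nc2ccccc2)C(=O)N(CCCn2ccnc2)C1c1ccc(Br)cc1)c1ccccc1` gives 25700 nM in this assay, the highest of the three numbers; the gap to compound 1 lies within the scatter, while the gap to compound 2 is larger: a 2.8-fold higher number from compound 2 to compound 3 (0.45 log units; beyond the scatter).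

Compound 4 `O=C(C1=C(Nc2ccc(Cl)cc2)C(=O)N(CCCn2ccnc2)C1c1ccc(Br)cc1)c1ccccc1` differs from compound 3 by one change: chloro in place of hydrogen on an aromatic carbon. Among the measured compounds shown here, none of the measured steps touches this place. The steps seen so far concern the group on the double-bonded ring carbon, a 1.2-fold higher number from compound 1 to compound 3 (0.07 log units; within the scatter) and a 2.8-fold higher number from compound 2 to compound 3 (0.45 log units; beyond the scatter), or the chain length, a 2.4-fold lower number from compound 1 to compound 2 (0.38 log units; beyond the scatter). So no measured step bears directly on the move from compound 3 to compound 4, and the expectation is a change of no more than the scatter, in no settled direction: a 1.1-fold lower number from compound 3 to compound 4 (0.03 log units; within the scatter). For compound 4 the estimate in this assay is therefore 24000 nM, expected to fall between 9000 nM and 65000 nM.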

Compound 4, half-maximal inhibitory concentration: 22800 nM
Estimate against measurement, compound 4: 1.1-fold (0.02 log units) above; measured number inside the range.
By their numbers in this assay, from the lowest: compound 2; then compounds 1, 4 and 3 (each within the scatter of the next).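

Among the compounds shown here, this is the first look at the outer ring of the anilino group, and in this assay going from phenyl to 4-chlorophenyl at this place leaves the two numbers within the scatter of each other (a 1.1-fold lower number from compound 3 to compound 4 (0.05 log units; within the scatter)). The (4-chlorophenyl)amino group also stands level with ethoxy (a 1.0-fold higher number from compound 1 to compound 4 (0.02 log units; within the scatter)), while pentyloxy keeps a lower number than this group, beyond the scatter (a 2.5-fold higher number from compound 2 to compound 4 (0.40 log units; beyond the scatter)), as it did against plain anilino. Nothing measured here speaks to the reason for this result.

One chloro cannot stand for this whole ring position, so a methoxy, a trifluoromethyl or an amine in its place could read alike or differently. Also open, going by these compounds, is whether a longer chain than pentyloxy, such as octyloxy, would lower the number further.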